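From 3-fluorophenyl to 4-fluorophenyl in one antiproliferative series

A few compounds are considered here, and "the series" means these few. Any claim that something is new, unique, unknown or untested is made for them only; others in the source may bear on it.

In a functional assay on HCT-116 cells (Homo sapiens) for antiproliferative activity, read by MTT assay, with a stated time of 72 h (a lower number here means a stronger inhibitor, a higher number a weaker inhibitor), compound 1 `O=C(CCc1cccc2c1B(O)OC2)Nc1cccc(-c2ccccc2)c1` gives 890 nM and compound 2 `O=C(CCc1cccc2c1B(O)OC2)Nc1cccc(-c2cccc(F)c2)c1` gives 460 nM as its number, which leaves compound 2 level with compound 1 within the scatter. Compound 3 `O=C(CCc1cccc2c1B(O)OC2)Nc1cccc(-c2ccc(F)cc2)c1` has 4-fluorophenyl in place of 3-fluorophenyl on an aromatic carbon and awaits measurement. For the measured compounds named here, the one measured step bearing on this is a 1.9-fold lower number from compound 1 to compound 2 (0.29 log units; within the scatter) for fluoro in place of hydrogen on an aromatic carbon, so no step beyond the scatter is expected. The expected step is a 1.1-fold higher number from compound 2 to compound 3 (0.05 log units; within the scatter) and stays within the scatter. For compound 3 the estimated value is 520 nM (expected range 220 nM to 1200 nM).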

Compound 3, half-maximal inhibitory concentration: 550 nM
Estimate against measurement, compound 3: 1.1-fold (0.02 log units) below, and the stated range covers the measured number.
By their numbers in this assay, from the lowest: compounds 2, 3 and 1 (each within the scatter of the next).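

In this assay, 4-fluorophenyl in place of 3-fluorophenyl gives a 1.2-fold higher number from compound 2 to compound 3 (0.08 log units; within the scatter), so the two fluorine placements cannot be told apart. Fluoro in place of hydrogen at this new place gives a 1.6-fold lower number from compound 1 to compound 3 (0.21 log units; within the scatter), which also stays within the scatter, so neither fluoro step separates from the parent compound. No supporting evidence bears on this result. Going by these compounds, whether an amine, a carboxylic acid or a methoxy group on this ring would move the number beyond the scatter remains open.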